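The source may report more compounds than this note shows. Statements on the series, on what has been measured and on what is new or still open speak of the compounds shown alone.

Of the compounds shown here, two have been measured so far in a functional assay on NALM-6 cells (Homo sapiens) for cytotoxicity, read by luminescence and CellTiter-Glo, with a stated time of 3 days (on this read-out lower numbers stand for stronger inhibition and higher numbers for weaker inhibition), with a clear difference between them. There compound 1 (`O=C(Nc1ccc(OC(F)(F)F)cc1Cl)c1cc(Cl)ccc1O`) gives 1350 nM and compound 2 (`O=C(Nc1ccc(Cl)cc1Cl)c1ccc2cccnc2c1O`) gives 450 nM as its number, the lower of the two, and the gap between them lies beyond the scatter. Compound 3 (`O=C(Nc1ccc(Cl)cc1)c1ccc2cccnc2c1O`) departs from compound 2 by a single change, hydrogen in place of chloro on an aromatic carbon in short: hydrogen in place of chloro on an aromatic carbon. Going by the values given here, no measured pair differs in one place only, so the data give no direct size for this change. A modest move toward weaker inhibition in this assay is expected, roughly at the edge of the scatter. The estimated step is a 1.8-fold higher number from compound 2 to compound 3 (0.25 log units; within the scatter) in that direction. For compound 3 the expected half-maximal inhibitory concentration is 800 nM with 250 nM to 2500 nM as the estimated range.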

Compound 3, half-maximal inhibitory concentration: 380 nM
Estimate against measurement, compound 3: 2.1-fold (0.32 log units) above; the measured number falls inside the stated range.
By their numbers in this assay, from the lowest: compounds 3 and 2 (each within the scatter of the next); then compound 1.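

In this assay, hydrogen in place of chloro on an aromatic carbon gives a 1.2-fold lower number from compound 2 to compound 3 (0.07 log units; within the scatter), the first size read for a single change in this set. At this place, ortho to a large group and meta to a chloro group, the chloro group is therefore not needed to keep the number of compound 2 within the scatter. The compounds offer no measurement that would account for this result.

As far as these compounds go, whether a different group at this place, such as an amine, a methoxy group or a longer chain, would give a step beyond the scatter remains open. Also open, from the compounds shown here alone, is what the chloro group that compound 2 and compound 3 share contributes, and how the core of compound 1 compares with theirs in a single change.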